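Methoxy in Place of Methyl on a Fused Aromatic Ring

The compounds below may be only part of what the source reports. "The series", "measured", "known", "first", "only" and "open" are said of these compounds alone.

Compound 1 `Cc1ccc2nc(Nc3nc(Nc4ccc(S(N)(=O)=O)cc4)ncc3F)sc2c1` gives 6390 nM in a functional assay on MDA-MB-231 cells (Homo sapiens) for antiproliferative activity, read by MTT assay, with a stated time of 48 h; a lower number here means a stronger inhibitor, a higher number a weaker inhibitor.
Compound 2 `Cc1cnc(Nc2ccc(S(C)(=O)=O)cc2)nc1Nc1nc2ccc(Cl)cc2s1` gives 5900 nM in this assay.
Compound 3 `Cc1ccc2nc(Nc3nc(Nc4ccc(S(N)(=O)=O)cc4)ncc3C)sc2c1` gives 9080 nM in this assay.

All three numbers sit close together. Going by the values given here, the one measured single-site step, a 1.4-fold higher number from compound 1 to compound 3 (0.15 log units; within the scatter), stays within the scatter, and the gap between compound 2 and compound 3 is also within the scatter, so none of the three can be called stronger or weaker than another.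

Compound 4 `COc1ccc2nc(Nc3nc(Nc4ccc(S(N)(=O)=O)cc4)ncc3C)sc2c1` differs from compound 3 by methoxy in place of methyl on an aromatic carbon. Among the compounds with values here, no measured pair in this set swaps methyl for methoxy; the only measured step, a 1.4-fold higher number from compound 1 to compound 3 (0.15 log units; within the scatter), changes a different group at another aromatic carbon and itself produced nothing beyond the scatter. There is therefore no direct precedent for this change, and the measured steps give no reason to expect movement in this assay in either direction.

For compound 4 the estimate is 9000 nM, with a range from 4000 nM to 20000 nM. The step this estimate implies, a 1.0-fold lower number from compound 3 to compound 4 (0.00 log units; within the scatter), is expected to fall within the scatter of the measurement.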

Compound 4, half-maximal inhibitory concentration: > 50000 nM
Compound 4: only a limit was reported (the forecaster's own chance of this, stated with the estimate: 5%); at least 5.5-fold (0.74 log units) between middle value and limit.
By their numbers in this assay, from the lowest: compounds 2, 1 and 3 (each within the scatter of the next). At a limit, above all of these: compound 4.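

Among the compounds shown, this is the first single-site change in this assay to go beyond the scatter: methoxy in place of methyl gives an at least 5.5-fold higher number from compound 3 to compound 4 (0.74 log units; beyond the scatter). So the methyl-bearing aromatic carbon of the fused system is a place where a small change can matter, which the earlier step at a different aromatic carbon, a 1.4-fold higher number from compound 1 to compound 3 (0.15 log units; within the scatter), gave no sign of. Compound 4 carries a limit of the assay rather than a number, so its step has a floor but no known upper end: the limit of > 50000 nM in this assay, at which 1 of the 4 values shown sits.

This single pair sets no general rule, and it cannot separate the effect of the added oxygen from the effect of the extra heavy atom, since methoxy brings both at once. The compounds shown leave open whether a hydroxy group, an ethoxy group or an amine on this carbon would stay in the range of compound 3 or move as compound 4 does, and whether the same swap would act alike with the fluoro group of compound 1 in place of the methyl group on the other ring.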